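This account rests on a few compounds, and the source may have more. Where it says the series, first, only, none or still open, it means among the compounds named here.

In an ADME assay on BJ cells (Homo sapiens) for cytotoxicity, with a stated time of 72 h (on this read-out lower numbers stand for an effect already at smaller amounts and higher numbers for an effect only at larger amounts of compound), compound 1 (`C=C[C@@](C)(/C=C/c1ccc(OCc2ccccc2)cc1)CCC=C(C)C`) gives > 36600 nM as a limit of the assay and not a number. Compound 1 therefore stands at the limit of > 36600 nM in this assay, at which 2 of the 3 values shown sit, and has no exact place on the scale. Compound 3 (`COc1ccc(/C=C/[C@@](C)(/C=C/c2ccc(O)cc2)CCC=C(C)C)cc1`) gives > 36600 nM in this assay and this is also a limit. Within the data shown here, compound 2 (`COc1ccc(/C=C/[C@@](C)(/C=C/c2ccc(O)c(/C=C/C(C)=O)c2)CCC=C(C)C)cc1`) is the only one of the three with a true number, 12300 nM in this assay so far.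

Compound 4 (`C=C[C@@](C)(/C=C/c1ccc(Nc2ccc(OC)cc2)cc1)CCC=C(C)C`) has (4-methoxyphenyl)amino in place of benzyloxy on an aromatic carbon of the core of compound 1. Among the measured compounds shown here, no measured step makes this swap. The nearest guide is an at least 2.9-fold higher number from compound 2 to compound 3 (0.47 log units; beyond the scatter) for hydrogen in place of 2-acetylethenyl on an aromatic carbon, which is a different change. For the measured compounds named here, it shows only that a change on an aromatic carbon can move a compound of this family clear of the scatter. Going by the values given here, with compound 2 at 12300 nM as the one measured number, a modest move is the most that can be expected here. A step toward a lower number is expected, estimated as an at least 2.0-fold lower number from compound 1 to compound 4 (0.30 log units; that floor lies within the scatter) with wide uncertainty. For compound 4 the estimated value is 18000 nM within an expected range of 6000 nM to 50000 nM in this assay when it is measured.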

Compound 4, half-maximal effective concentration: > 36600 nM
Compound 4: a limit, no number (the forecaster's own chance of this, stated with the estimate: 45%); middle value at least 2.0-fold (0.30 log units) from the limit.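

Among these compounds, compound 4, like compound 1, gives a limit of the assay and not a number, so no step between the two can be read, and both stand at the same mark: the limit of > 36600 nM in this assay, at which 3 of the 4 values shown sit. Going by these compounds, whether (4-methoxyphenyl)amino in place of benzyloxy moves the read-out at all, and in which direction, stays open.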